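Swapping an Ether Link for an Amine Link on Two Cores

A few compounds are considered here, and "the series" means these few. Any claim that something is new, unique, unknown or untested is made for them only; others in the source may bear on it.

Of the compounds shown here, three have been measured in a functional assay on A-431 cells (Homo sapiens) (on this read-out lower numbers stand for an effect already at smaller amounts and higher numbers for an effect only at larger amounts of compound), and a fourth awaits measurement. Compound 2 `COc1cc(OC)cc(Oc2ncccc2-c2n[nH]c(Nc3ccc4c(c3)OCCO4)n2)c1` gives 3.6 nM in this assay. Compound 1 `COc1cc(Nc2ncccc2-c2n[nH]c(Nc3ccc4c(c3)OCCO4)n2)cc(OC)c1` differs from it by one change, ((3,5-dimethoxyphenyl)amino in place of 3,5-dimethoxyphenoxy on an aromatic carbon), and compound 1 gives 117 nM. That single exchange produced a 33-fold higher number from compound 2 to compound 1 (1.51 log units; beyond the scatter), so the amine-linked compound needs far more material for the same effect than the ether-linked one.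

Compound 3 `COc1cc(OC)cc(Oc2ncncc2-c2n[nH]c(Nc3ccc4c(c3)OCCO4)n2)c1` carries the same ether link but sits on a different core; the difference between the two cores is not broken down here. In this assay compound 3 gives 44 nM, which is a higher number than that of compound 2 and a lower number than that of compound 1, with both gaps beyond the scatter.

Compound 4 `COc1cc(Nc2ncncc2-c2n[nH]c(Nc3ccc4c(c3)OCCO4)n2)cc(OC)c1` is compound 3 with (3,5-dimethoxyphenyl)amino in place of 3,5-dimethoxyphenoxy on an aromatic carbon. This is the same kind of change as from compound 2 to compound 1, not the same: here the ring carries 2 nitrogen rather than 1 nitrogen, and the place is also opposite the ring nitrogen. Going by the values given here, only one example of this exchange exists, so the expectation rests on that alone. An estimated 23-fold higher number from compound 3 to compound 4 (1.36 log units; beyond the scatter) is expected, somewhat softened because the step of a 33-fold higher number from compound 2 to compound 1 (1.51 log units; beyond the scatter) was measured on another core. Compound 4 is therefore expected to give about 1000 nM, most likely between 300 nM and 4000 nM.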

Compound 4, half-maximal effective concentration: 53 nM
For compound 4 the middle estimate is 19-fold (1.28 log units) above the measured one; the whole stated range lies above it.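

In this assay, putting (3,5-dimethoxyphenyl)amino in place of 3,5-dimethoxyphenoxy on the core with 2 ring nitrogen gives a 1.2-fold higher number from compound 3 to compound 4 (0.08 log units; within the scatter), so on this core the exchange leaves no change that can be told apart from the usual scatter of repeated measurements. The same exchange on the core with 1 ring nitrogen had a large effect, which means that its size did not carry over from one core to the other: the same change on two cores in this assay, a 33-fold higher number (1.51 log units; beyond the scatter) from compound 2 to compound 1 and a 1.2-fold higher number (0.08 log units; within the scatter) from compound 3 to compound 4, 27-fold (1.43 log units) apart, beyond the scatter of two such steps. Going by these compounds alone, this shows that, in this small series, a step measured on one core cannot simply be transferred to another, but with only two pairs of compounds it does not show which feature of the cores is responsible, or what the exchange would do on a third core.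

The compounds shown leave open how a link of another kind, such as a methylene or a carbonyl, would behave on these two cores. Also open, as far as these compounds go, is whether the two cores would again part ways if a plain phenyl stood in place of the 3,5-dimethoxyphenyl group on both the ether and the amine link.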